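Aryl amide against benzyl amide in a small series

The source may report more compounds than this note shows. Statements on the series, on what has been measured and on what is new or still open speak of the compounds shown alone.

Compound 1 `COc1ccc2c(=O)c(/C=C/C(=O)Nc3ccc(C)cc3)coc2c1` carries a 4-methylphenyl on the amide nitrogen, and in a functional assay on A549 cells (Homo sapiens) for inhibition, read by MTT assay, with a stated time of 48 h (on this read-out higher numbers stand for weaker inhibition and lower numbers for stronger inhibition), compound 1 gives 17500 nM. Compound 2 `COc1ccc2c(=O)c(/C=C/C(=O)NCc3ccc(F)cc3)coc2c1` has 4-fluorobenzyl in that place; in this assay compound 2 gives only a limit, > 100000 nM. Compound 3 `COc1ccc2c(=O)c(/C=C/C(=O)NCc3ccc(C)cc3)coc2c1` has 4-methylbenzyl; in this assay compound 3 likewise reaches only the limit, > 100000 nM. Compound 3 thus stands at the weak end of what is shown, at the limit of > 100000 nM in this assay, at which 2 of the 3 values shown sit. The steps of an at least 5.7-fold higher number from compound 1 to compound 2 (0.75 log units; beyond the scatter) and an at least 5.7-fold higher number from compound 1 to compound 3 (0.75 log units; beyond the scatter) point the same way: a benzyl in place of the aryl group costs inhibition. The step that the two limits leave unreadable from compound 2 to compound 3 cannot be read from the two limits. Compound 4 `COc1ccc2c(=O)c(/C=C/C(=O)Nc3ccc(F)cc3)coc2c1` is the next member: 4-fluorophenyl in place of 4-methylbenzyl on an amide-type nitrogen. It restores the aryl amide pattern of compound 1 while exchanging methyl for fluoro; the first part, through an at least 5.7-fold higher number from compound 1 to compound 3 (0.75 log units; beyond the scatter) taken in reverse, should bring a clear gain, and the second part has no readable precedent here. Given the value of compound 1, 17500 nM, compound 4 is expected at 20000 nM, within 7000 nM to 60000 nM. The expected step is an at least 5.0-fold lower number from compound 3 to compound 4 (0.69 log units; beyond the scatter).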

Compound 4, half-maximal inhibitory concentration: 26800 nM
Estimate against measurement, compound 4: 1.3-fold (0.13 log units) below, within the range that was stated.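

In this assay, the loss on going from an aryl to a benzyl group on the amide-type nitrogen now appears with fluoro on the ring as well as with methyl, seen in reverse as an at least 3.7-fold lower number from compound 2 to compound 4 (0.57 log units; beyond the scatter) and an at least 3.7-fold lower number from compound 3 to compound 4 (0.57 log units; beyond the scatter). Fluoro in place of methyl on the aryl amide gives a 1.5-fold higher number from compound 1 to compound 4 (0.19 log units; within the scatter), so the aryl amide holds its level with either group on the ring. Compound 2 and compound 3 each give a limit of the assay, not a number: the limit of > 100000 nM in this assay, at which 2 of the 4 values shown sit.

Any difference between the two benzyl amides cannot be read from those limits. From the compounds shown here alone, how a longer chain on the amide-type nitrogen, or an aromatic ring carrying an amine or a carboxylic acid, would read in this assay stays open.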